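Swapping the Spiro Ring on the Amide for a Methylcyclohexyl

The source may report more compounds than this note shows. Statements on the series, on what has been measured and on what is new or still open speak of the compounds shown alone.

Among the compounds with values here, compound 2 `O=C(C1CC12CCC2)N1CCc2nc(C#Cc3ccccc3)sc2C1` gives 3.9 nM in an assay on HEK293 cells for positive allosteric modulation of metabotropic glutamate receptor 5 (Homo sapiens), read by FLIPR, with a stated time of 1 h (a lower number here means that less compound is needed, a higher number that more compound is needed for the effect), the lowest of the two numbers measured so far; the only other measured compound, compound 1 `CN1CCc2nc(C#Cc3ccccc3)sc2C1`, gives 34 nM. Within the data shown here, the single measured step, an 8.7-fold lower number from compound 1 to compound 2 (0.94 log units; beyond the scatter), concerns the amine nitrogen, whereas compound 3 `CC1CCC(C(=O)N2CCc3nc(C#Cc4ccccc4)sc3C2)CC1` changes the group on the carbonyl carbon instead: a group of 7 heavy atoms (7 carbon; one six-membered non-aromatic ring of carbon only) in place of a group of 6 heavy atoms (6 carbon; one three-membered non-aromatic ring of carbon only, one four-membered non-aromatic ring of carbon only), on a carbonyl carbon. Among the measured compounds shown here, no measured step tests an exchange of this kind, so the step of a 1.3-fold higher number from compound 2 to compound 3 (0.11 log units; within the scatter) is expected to stay small, close to the scatter. For compound 3 the estimate is 5 nM, within a range from 1.5 nM to 16 nM.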

Compound 3, half-maximal effective concentration: 190 nM
Compound 3: middle estimate off by 38-fold (1.58 log units), on the low side, and the stated range ends below it.
By their numbers in this assay, from the lowest: compound 2; then compound 1; then compound 3.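

Within the data shown here, the group on the carbonyl carbon matters far more than the earlier compounds could show: with the shared core and the amide kept, exchanging the group with the three-membered and four-membered rings for 4-methylcyclohexyl gives a 49-fold higher number from compound 2 to compound 3 (1.69 log units; beyond the scatter). This position therefore does not treat all carbon-only ring groups alike, although neither group has a hydrogen-bond donor or acceptor. Nothing available here explains the gap.

Still open, on these data alone, is whether the loss goes with the six-membered ring itself or with its methyl group, which a plain cyclohexyl would separate. As far as these compounds go, how a group carrying an amine or a carboxylic acid would fare at this carbonyl carbon is also open.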